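Fluoro in Place of Cyano: What to Expect for Compound 3

The source may hold more compounds than are shown below. What is called first, only, known or untested is meant among the compounds shown, and "the series" means these compounds.

Compound 1 `CC1CCN(c2c(S(=O)(=O)c3cccc(F)c3)cnc3ccc(F)cc23)CC1`: in an assay on isolated protein for displacement of a labelled ligand from metabotropic glutamate receptor 5 (Homo sapiens), with a stated time of 60 min, tested at 1 uM (on this read-out higher numbers stand for more inhibition at the one concentration tested (going by the name of the read-out) and lower numbers for less inhibition), compound 1 gives 76%.
Compound 2 `Cc1ccc2ncc(S(=O)(=O)c3cccc(C#N)c3)c(N3CCC(C)CC3)c2c1`: in this assay compound 2 gives 52%.

Among the compounds with values here, only these two compounds have numbers so far. Compound 2 stands lowest of the two, and the gap to compound 1 is beyond the usual scatter of this kind of measurement. The two differ in more than one place, so no single structural change can be tied to that gap.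

Compound 3 `Cc1ccc2ncc(S(=O)(=O)c3cccc(F)c3)c(N3CCC(C)CC3)c2c1` has not yet been measured. It differs from compound 2 in one place: fluoro in place of cyano on an aromatic carbon. Compound 3 therefore carries the same 3-fluorophenyl group as compound 1, while keeping the core of compound 2.

Within the data shown here, with no single-change step between measured compounds to lean on, the direction of this change is uncertain. Because compound 1, which also bears the 3-fluorophenyl group, gives 76%, a modest rise from compound 2 is expected, though a step within the scatter would not surprise. The expected step is a number 12 percentage points higher from compound 2 to compound 3 (beyond the scatter). Compound 3 is estimated at 64%, within a range from 44% to 84%.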

Compound 3, a percentage reported as inhibition, at one concentration (the size of the read-out at that concentration, not a potency): 94%
Compound 3: middle estimate off by 30 percentage points, on the low side; measured number above the stated range.
By their numbers in this assay, from the lowest: compound 2; then compound 1; then compound 3.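

With the 3-cyanophenyl group changed to 3-fluorophenyl, this assay shows a number 42 percentage points higher from compound 2 to compound 3 (beyond the scatter), so the group on this ring carbon, meta to a large group, strongly affects the read-out, and fluoro does clearly better than cyano in this setting. With the 3-fluorophenyl group held constant, methyl in place of fluoro on an aromatic carbon elsewhere in the molecule gives a number 18 percentage points higher from compound 1 to compound 3 (beyond the scatter), showing that a second single change, at a different place, also shifts the number beyond the usual scatter. These steps give the size and direction of each change, but no measurement available here bears on what lies behind either of them.

The compounds shown compare only cyano and fluoro at this position, so it remains open how a chlorine atom, a methoxy group or a plain hydrogen would fare there. As far as these compounds go, it also remains open whether fluoro in place of cyano would give a similar step with fluoro rather than methyl on the core, and how the compounds would rank at other concentrations.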